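Bromo to Chloro: Expecting an Unchanged Cytotoxicity Limit

This account rests on a few compounds, and the source may have more. Where it says the series, first, only, none or still open, it means among the compounds named here.

Compound 1 `CC(=O)c1cccc(-c2ccc(C(=O)N(Cc3cccc(OCCCCCC(=O)O)c3)C(C)C)cc2)c1` — > 26000 nM
Compound 2 `CC(C)N(Cc1cccc(OCCCCCC(=O)O)c1)C(=O)c1ccc(-c2cccc(Br)c2)cc1` — > 26000 nM

In an ADME assay on HEK293 cells (Homo sapiens) for cytotoxicity, read by CellTiter-Glo and resazurin assay, with a stated time of 72 h (a higher number here means that more compound is needed for the effect, a lower number that less compound is needed), compound 1 reaches only a limit, > 26000 nM. Compound 2 likewise gives only a limit in this assay, > 26000 nM. For the measured compounds named here, the step that the two limits leave unreadable from compound 1 to compound 2 therefore cannot be read, and the only evidence available is the limit of > 26000 nM in this assay, at which 2 of the 2 values shown sit, so compound 2 stands at that limit and nowhere more precisely.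

Compound 3 `CC(C)N(Cc1cccc(OCCCCCC(=O)O)c1)C(=O)c1ccc(-c2cccc(Cl)c2)cc1` differs from compound 2 by chloro in place of bromo on an aromatic carbon. Going by the values given here, no measured step bears readably on this change: the one step recorded, from compound 1 to compound 2, is hidden by the two limits. With nothing pointing to a shift, the step that the limit leaves unreadable from compound 2 to compound 3 is expected to stay within the scatter. Compound 3 is accordingly expected to remain at or beyond the limit, estimated at 40000 nM with a range from 20000 nM to 120000 nM.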

Compound 3, half-maximal effective concentration: > 21900 nM
Compound 3 gave a limit, no number (the forecaster's own chance of this, stated with the estimate: 85%); the middle value lies beyond the limit too.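

For the compounds shown here, compound 2 and compound 3 both end at limits in this assay, as does compound 1, so no step among the three can be read. The compounds shown leave open what concentration, if any, would produce the effect for acetyl, bromo or chloro.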